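The compounds below may be only part of what the source reports. "The series", "measured", "known", "first", "only" and "open" are said of these compounds alone.

Measured in an ADME assay on MT4 cells (Homo sapiens) for cytotoxicity, read by MTT assay, with a stated time of 5 days; on this read-out higher numbers stand for lower toxicity in this test and lower numbers for higher toxicity in this test:
compound 1 `Cc1cc(C)cc(S(=O)(=O)c2c(C(N)=O)[nH]c3ccc(Cl)cc23)c1` gives 13000 nM
compound 2 `Cc1cc(C)cc(S(=O)(=O)c2c(C(=O)N[C@@H]3CCNC3)[nH]c3ccc(Cl)cc23)c1` gives 37300 nM
compound 3 `Cc1cc(C)cc(S(=O)(=O)c2c(C(=O)NC3CN(S(C)(=O)=O)C3)[nH]c3ccc(Cl)cc23)c1` gives > 252000 nM (a limit)

Compound 3 gives a limit, not a number (the limit of > 252000 nM in this assay, at which 1 of the 3 values shown sits). Compound 4 `Cc1cc(C)cc(S(=O)(=O)c2c(C(=O)NS(=O)(=O)C(F)(F)F)[nH]c3ccc(Cl)cc23)c1` differs from it on an amide-type nitrogen ((trifluoromethyl)sulfonyl in place of 1-(methylsulfonyl)azetidin-3-yl on an amide-type nitrogen): (trifluoromethyl)sulfonyl in place of 1-(methylsulfonyl)azetidin-3-yl. The measured steps at that nitrogen are a 2.9-fold higher number from compound 1 to compound 2 (0.46 log units; beyond the scatter) (modest), an at least 19-fold higher number from compound 1 to compound 3 (1.28 log units; beyond the scatter) (large) and an at least 6.7-fold higher number from compound 2 to compound 3 (0.82 log units; beyond the scatter) (at least modest). Their size varies with the group, and none introduces (trifluoromethyl)sulfonyl. Compound 2 (37300 nM) shows that a group on this nitrogen can also give a measured number. A modest to large drop in this assay is therefore expected (an at least 4.2-fold lower number from compound 3 to compound 4 (0.62 log units; beyond the scatter)). The estimate for compound 4 is 60000 nM (expected range 13000 nM to 250000 nM).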

Compound 4, half-maximal cytotoxic concentration: 141000 nM
The estimate for compound 4 lay 2.4-fold (0.37 log units) below the measured number, within the range that was stated.
By their numbers in this assay, from the lowest: compound 1; then compound 2; then compound 4. At a limit, above all of these: compound 3.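

In this assay, (trifluoromethyl)sulfonyl on the amide-type nitrogen shows that a group with no ring can also raise the number over the unsubstituted amide (an 11-fold higher number from compound 1 to compound 4 (1.04 log units; beyond the scatter)) and over the pyrrolidin-3-yl amide (a 3.8-fold higher number from compound 2 to compound 4 (0.58 log units; beyond the scatter)). Against 1-(methylsulfonyl)azetidin-3-yl, the order remains unsettled (an at least 1.7-fold lower number from compound 3 to compound 4 (0.25 log units; that floor lies within the scatter)). Compound 3 gives a limit, not a number: the limit of > 252000 nM in this assay, at which 1 of the 4 values shown sits.

On these data alone, how a plain methylsulfonyl group or a longer alkyl chain on this nitrogen would read remains open. The trifluoromethyl and sulfonyl parts of the change therefore cannot yet be separated.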